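This account rests on a few compounds, and the source may have more. Where it says the series, first, only, none or still open, it means among the compounds named here.

Series notes. Compound 3 `Cc1ncnn1-c1cc(F)ccc1CNC(=O)c1nc(C2CCOC2)n(C)c(=O)c1O` gives 0.23 h in an ADME assay on the whole organism (strain Sprague-Dawley) for metabolic stability, with Rattus norvegicus as the target, at a dose of 1 mg/kg by the intravenous route (on this read-out lower numbers stand for a shorter-lived compound and higher numbers for a longer-lived compound), the second highest of the three numbers; compound 1 `Cn1c(C2CCOCC2)nc(C(=O)NCc2ccc(F)cc2N2CCN(C(C)(C)C)S2(=O)=O)c(O)c1=O` gives 0.22 h, within the scatter of compound 3, whereas compound 2 `Cn1c(C2CCOCC2)nc(C(=O)NCc2ccc(F)cc2)c(O)c1=O` gives 0.58 h, beyond it. Compound 4 `COCCN1CCN(c2cc(F)ccc2CNC(=O)c2nc(C3CCOC3)n(C)c(=O)c2O)C1=O` carries 3-(2-methoxyethyl)-2-oxoimidazolidin-1-yl in place of 5-methyl-1H-1,2,4-triazol-1-yl on an aromatic carbon. For the measured compounds named here, the only measured step at such an aromatic carbon is a 2.6-fold higher number from compound 1 to compound 2 (0.42 log units; beyond the scatter), where the loss of a large ring-bearing group went with a longer half-life; the present change instead enlarges the group. That step points, if anywhere, downward, but compound 3 already sits close to compound 1 with its smaller group, so for compound 4 a step of a 1.3-fold lower number from compound 3 to compound 4 (0.11 log units; within the scatter) is expected, not beyond the scatter. Compound 4 is expected to give 0.18 h in this assay, between 0.08 h and 0.45 h.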

Compound 4, half-life: 0.46 h
Estimate against measurement, compound 4: 2.6-fold (0.41 log units) below, and the stated range ends below it.
By their numbers in this assay, from the lowest: compounds 1, 3, 4 and 2 (each within the scatter of the next, the first and the last beyond it).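

In this assay, exchanging 5-methyl-1H-1,2,4-triazol-1-yl for the larger 3-(2-methoxyethyl)-2-oxoimidazolidin-1-yl on this aromatic carbon gives a 2.0-fold higher number from compound 3 to compound 4 (0.30 log units; within the scatter). The earlier step here, a 2.6-fold higher number from compound 1 to compound 2 (0.42 log units; beyond the scatter), replaced a group with hydrogen, whereas this one exchanges one ring-bearing group for another and stays within the scatter, so more heavy atoms at this carbon need not shorten the half-life. Nothing available explains this result.

Still open, going by these compounds, is how an amine or a carboxylic acid would read on this carbon. Also open, on these data alone, is whether a methyl in place of the 2-methoxyethyl chain would alter the half-life.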